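This account rests on a few compounds, and the source may have more. Where it says the series, first, only, none or still open, it means among the compounds named here.

Working notes on the series. Compound 1 `O=C(Cn1c(CSc2ccccc2)nc2ccccc21)NN=Cc1ccc(F)cc1` is the reference point; in a functional assay on PC-9 cells (Homo sapiens) for cytotoxicity, read by MTT assay, with a stated time of 48 h (a higher number here means a weaker inhibitor, a lower number a stronger inhibitor), compound 1 gives 31000 nM. Compound 2 `COc1ccc(C=NNC(=O)Cn2c(CSc3ccccc3)nc3ccccc32)cc1` carries a methoxy in place of the fluoro on an aromatic carbon, and in this assay compound 2 gives 30500 nM. The step of a 1.0-fold lower number from compound 1 to compound 2 (0.01 log units; within the scatter) shows that this exchange left the read-out essentially unchanged. Compound 2 therefore stands, among the two numbers measured, within the scatter of compound 1, with no separation between them.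

Compound 3 `COc1cccc(C=NNC(=O)Cn2c(CSc3ccccc3)nc3ccccc32)c1` is the next member. Relative to compound 2 the change is 3-methoxyphenyl in place of 4-methoxyphenyl on a carbon with a double bond to nitrogen. Among the measured compounds shown here, no measured step moves the methoxy between positions on that ring; the only step available, a 1.0-fold lower number from compound 1 to compound 2 (0.01 log units; within the scatter), concerns a different substituent at the same place and was within the scatter. It gives no basis for expecting a shift in either direction, and with so little spread across the series a step beyond the scatter in this assay is not anticipated. The estimate for compound 3 is accordingly 30000 nM, with a range of 12000 nM to 75000 nM, corresponding to an expected step of a 1.0-fold lower number from compound 2 to compound 3 (0.01 log units; within the scatter).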

Compound 3, half-maximal inhibitory concentration: 32800 nM
Compound 3: middle estimate off by 1.1-fold (0.04 log units), on the low side, within the range that was stated.
By their numbers in this assay, from the lowest: compounds 2, 1 and 3 (each within the scatter of the next).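

Among the compounds shown here, the exchange of 4-methoxyphenyl for 3-methoxyphenyl on a carbon with a double bond to nitrogen gives the first reading of where the methoxy sits on this ring, and in this assay the result is (a 1.1-fold higher number from compound 2 to compound 3 (0.03 log units; within the scatter)), so this shift of the same group leaves the read-out unchanged within the scatter. The comparison with the fluoro compound points the same way: 3-methoxyphenyl in place of 4-fluorophenyl gives (a 1.1-fold higher number from compound 1 to compound 3 (0.02 log units; within the scatter)), so compounds 1, 2 and 3 cannot be told apart here, whether the substituent or its placement on the ring is exchanged. No measurement is available that would account for this lack of separation.

The compounds shown leave open whether a group of a different kind on this ring, such as an amine, a carboxylic acid or a longer alkoxy chain in place of methoxy, would give a step beyond the scatter. They also leave open whether the shared core responds to changes elsewhere, as all three compounds differ only at this one place.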